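Fluorine Position and Ester Cleavage in Antiproliferative Thiazoles

The compounds below may be only part of what the source reports. "The series", "measured", "known", "first", "only" and "open" are said of these compounds alone.

Measured compounds:
Compound 1, `CCOC(=O)c1sc(-c2cccc(NC(=O)c3cccc(F)c3)c2)nc1Nc1ccc(N2CCN(C)CC2)cc1`: 82.8%
Compound 2, `CCOC(=O)c1sc(-c2cccc(NC(=O)c3ccccc3F)c2)nc1Nc1ccc(N2CCN(C)CC2)cc1`: 89.8%
Compound 3, `CN1CCN(c2ccc(Nc3nc(-c4cccc(NC(=O)c5cccc(F)c5)c4)sc3C(=O)O)cc2)CC1`: 76.3%

All three were tested in a functional assay on Raji cells (Homo sapiens) for antiproliferative activity, read by CCK-8 assay, with a stated time of 72 h, tested at 40 uM; on this read-out lower numbers stand for less inhibition and higher numbers for more inhibition at the one concentration tested (going by the name of the read-out). Compound 1 and compound 2 share one core and differ only in the fluorine position on the amide-bearing ring: 2-fluorophenyl in place of 3-fluorophenyl on a carbonyl carbon. That change gave a number 7 percentage points higher from compound 1 to compound 2 (within the scatter). Compound 3 carries a different core, set apart from compound 1 by hydrogen in place of ethyl on an oxygen next to a carbonyl group; in this assay compound 3 gives 76.3%, and its step from compound 1 is a number 6.5 percentage points lower from compound 1 to compound 3 (within the scatter).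

Compound 4, `CN1CCN(c2ccc(Nc3nc(-c4cccc(NC(=O)c5ccccc5F)c4)sc3C(=O)O)cc2)CC1`, has not been measured. It differs from compound 3 by 2-fluorophenyl in place of 3-fluorophenyl on a carbonyl carbon, the same change that turns compound 1 into compound 2, made here on the core of compound 3; the place around the change is the same in both pairs. Since the earlier step was a number 7 percentage points higher from compound 1 to compound 2 (within the scatter), the expected step from compound 3 to compound 4 is estimated as a number 4.7 percentage points higher from compound 3 to compound 4 (within the scatter), resting only on that single pair. On this basis compound 4 is expected to give roughly 81%, between 70% and 92%.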

Compound 4, a percentage reported as inhibition, at one concentration (the size of the read-out at that concentration, not a potency): 86.9%
Beside the measured number, compound 4's estimate is 5.9 percentage points below it, within the range that was stated.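

Swapping 3-fluorophenyl for 2-fluorophenyl on the core of compound 3 gave a number 10.6 percentage points higher from compound 3 to compound 4 (beyond the scatter) in this assay, and the size of this step matches the one seen with the same swap on the core of compound 1: the same change on two cores in this assay, a number 7 percentage points higher (within the scatter) from compound 1 to compound 2 and a number 10.6 percentage points higher (beyond the scatter) from compound 3 to compound 4, 3.6 percentage points apart, within the scatter of two such steps. Replacing the ethyl on the ester oxygen with hydrogen, which turns the ester into a carboxylic acid, also carries over, now on the 2-fluorophenyl compounds, with a number 2.9 percentage points lower from compound 2 to compound 4 (within the scatter): the same change on two cores in this assay, a number 6.5 percentage points lower (within the scatter) from compound 1 to compound 3 and a number 2.9 percentage points lower (within the scatter) from compound 2 to compound 4, 3.6 percentage points apart, within the scatter of two such steps. So in these four compounds each change has much the same size on both cores, but only one of the four steps lies beyond the scatter, and two pairs at a single concentration give neither a general rule for other cores nor a measure of potency.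

The compounds shown leave open how a plain phenyl group would compare with either fluorophenyl group. They also leave open whether a primary amide in place of the ester or carboxylic acid would fit the same picture.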